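The source may hold more compounds than are shown below. What is called first, only, known or untested is meant among the compounds shown, and "the series" means these compounds.

Compound 1 `CCCCCCCCCCCCC/C=C/[C@H](O)[C@H](COP(=O)(O)O)N=[N+]=[N-]` gives 20400 nM in an assay on isolated protein for inhibition of sphingosine-1-phosphate lyase 1 (Homo sapiens), using Lineweaver-Burk analysis; a higher number here means a weaker inhibitor, a lower number a stronger inhibitor. Compound 2 `CCCCCCCCCCCCC/C=C/[C@@H](O)[C@@H](COP(=O)(O)O)N=[N+]=[N-]` gives 17500 nM in this assay.

On these two numbers compound 2 stands level with compound 1, since a 1.2-fold lower number from compound 1 to compound 2 (0.07 log units; within the scatter) lies within the scatter even though both stereocentres are inverted in that step. Compound 3 `CCCCCCCCCCCCC/C=C/[C@H](O)[C@@H](COP(=O)(O)O)N=[N+]=[N-]` differs from compound 2 in the two compounds have the same atoms and bonds; at least one stereo element is drawn with a configuration in one of them and without one in the other: 1 of 4 stereo elements differ; a stereocentre at a saturated chain carbon is drawn R in compound 2 and S in compound 3. Going by the values given here, the only measured step that bears on such a change, a 1.2-fold lower number from compound 1 to compound 2 (0.07 log units; within the scatter), was too small to rise above the scatter, so no change beyond the scatter is expected in this assay. Compound 3 is therefore estimated at 18000 nM, within 7000 nM to 45000 nM, which means a step of a 1.0-fold higher number from compound 2 to compound 3 (0.01 log units; within the scatter).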

Compound 3, inhibition constant: 5600 nM
Estimate against measurement, compound 3: 3.2-fold (0.51 log units) above; measured number below the stated range.
By their numbers in this assay, from the lowest: compound 3; then compounds 2 and 1 (each within the scatter of the next).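

Changing a single stereocentre at a saturated chain carbon does move the number in this assay: a 3.1-fold lower number from compound 2 to compound 3 (0.49 log units; beyond the scatter), and a 3.6-fold lower number from compound 1 to compound 3 (0.56 log units; beyond the scatter). Both steps are modest but beyond the scatter, whereas inverting both stereocentres together had left compounds 1 and 2 level, so the arrangement of the two centres relative to each other counts, not either centre alone. The numbers themselves give no reason for this difference.

As far as these compounds go, it remains open whether the preference for compound 3 would hold with an amine in place of the azide, or with a longer chain.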